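Aryl Sulfonamide Swap Weighed Against a Single Measured Anchor

A few compounds are considered here, and "the series" means these few. Any claim that something is new, unique, unknown or untested is made for them only; others in the source may bear on it.

Going by the values given here, compound 1 `O=S(=O)(Nc1ccc(-c2nc3ccccc3o2)cc1)c1cccc(F)c1` is the only member of this small set with a measured number: in an assay on cells for inhibition of HSP60/HSP10 (Homo sapiens), with a stated time of 60 min (a higher number here means a weaker inhibitor, a lower number a stronger inhibitor), compound 1 gives 71000 nM. Compound 2 `COc1ccc(S(=O)(=O)Nc2ccc3oc(-c4ccccc4)nc3c2)cc1` differs from compound 1 in several places at once. In this assay compound 2 gives > 100000 nM, a limit of the assay rather than a number, and stands for (the limit of > 100000 nM in this assay, at which 1 of the 2 values shown sits). Among the compounds with values here, no step between two measured compounds is therefore available, and compound 1 alone anchors what follows.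

Compound 3 `COc1ccc(Cl)cc1S(=O)(=O)Nc1ccc(-c2nc3ccccc3o2)cc1` keeps the rest of compound 1 and differs in one place: 5-chloro-2-methoxyphenyl in place of 3-fluorophenyl on a sulfonyl sulfur. Within the data shown here, with no measured step to lean on, the expectation in this assay is a change of no size beyond the usual scatter, in either direction, together with some chance that compound 3 also returns only a limit. Compound 3 is accordingly estimated at 60000 nM, with a range from 20000 nM to 150000 nM. That estimate amounts to an expected step of a 1.2-fold lower number from compound 1 to compound 3 (0.07 log units; within the scatter), a movement that would not stand out from repeat measurements.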

Compound 3, half-maximal inhibitory concentration: > 100000 nM
Compound 3: no number, only a limit; the forecaster's own chance of this, stated with the estimate: 35%; at least 1.6-fold (0.22 log units) between middle value and limit.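

Compound 3 gives > 100000 nM, a limit of the assay and not a number. In this assay, going by these compounds alone, 5-chloro-2-methoxyphenyl in place of 3-fluorophenyl on a sulfonyl sulfur gives the only step that can be read in this set, and it is a floor rather than a measured size: an at least 1.4-fold higher number from compound 1 to compound 3 (0.14 log units; that floor lies within the scatter). Within the data shown here, the swap therefore shows no gain over compound 1 at this position and cannot establish a real loss, while the only measured value in the set remains that of compound 1, with the others resting at the same ceiling: the limit of > 100000 nM in this assay, at which 2 of the 3 values shown sit.

Going by these compounds, how far compound 3 lies beyond its limit stays open, as does whether the chlorine or the methoxy on the entering ring would, taken alone, move the number in either direction. Also open, on these data alone, is whether any other group on the sulfonyl sulfur, such as an unsubstituted phenyl, a ring carrying an amine or a carboxylic acid, or a short alkyl chain, would bring the number below that of compound 1.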